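The source may report more compounds than this note shows. Statements on the series, on what has been measured and on what is new or still open speak of the compounds shown alone.

Measured compounds in the series:
- compound 1, `Cc1ccc(CS(=O)(=O)/C(=C/c2cc(C)cc(C)c2)C(=O)c2ccc(Cl)cc2)cc1`: 10000 nM
- compound 2, `Cc1ccc(CS(=O)(=O)/C(=C/c2ccc(N(C)C)cc2)C(=O)c2ccc(Cl)cc2)cc1`: 50000 nM
- compound 3, `Cc1cc(C)cc(/C=C(/Sc2ccc(Br)cc2)C(=O)c2ccc(Cl)cc2)c1`: 10000 nM

All three numbers come from a functional assay on DU-145 cells (Homo sapiens) for inhibition, read by trypan blue exclusion, with a stated time of 96 h; on this read-out higher numbers stand for weaker inhibition of growth and lower numbers for stronger inhibition of growth. Compound 1 and compound 2 differ in one place, (4-(dimethylamino)phenyl in place of 3,5-dimethylphenyl on a double-bonded chain carbon bound to a double-bonded chain carbon), and this gave a 5.0-fold higher number from compound 1 to compound 2 (0.70 log units; beyond the scatter). Among the measured compounds shown here, compound 3, in this assay, gives 10000 nM, level with compound 1 at the digits reported, and compound 2 is the only higher number of the three. The difference between the core of compound 1 and the core of compound 3 is not broken down here.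

Compound 4, `CN(C)c1ccc(/C=C(/Sc2ccc(Br)cc2)C(=O)c2ccc(Cl)cc2)cc1`, has not yet been measured. It stands to compound 3 as compound 2 stands to compound 1: 4-(dimethylamino)phenyl in place of 3,5-dimethylphenyl on a double-bonded chain carbon bound to a double-bonded chain carbon, at the same place in both pairs, so this is the same change. Because the step of a 5.0-fold higher number from compound 1 to compound 2 (0.70 log units; beyond the scatter) was modest but beyond the scatter, a step of similar size, a 5.0-fold higher number from compound 3 to compound 4 (0.70 log units; beyond the scatter), is expected here. For compound 4 the estimate in this assay is 50000 nM, between 15000 nM and 150000 nM.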

Compound 4, concentration for 50% growth inhibition: > 100000 nM
Compound 4: a limit, no number; the forecaster's own chance of this, stated with the estimate: 30%; middle value at least 2.0-fold (0.30 log units) away from the limit.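

In this assay, the change to 4-(dimethylamino)phenyl raises the number on the second core as well, an at least 10-fold higher number from compound 3 to compound 4 (1.00 log units; beyond the scatter). Compound 4 gives > 100000 nM, which is a limit of the assay and not a number, so the size of the step on this core stays unfixed. The direction therefore carries over between these two cores, while equal or unequal step sizes cannot be told apart: the same change on two cores in this assay, a 5.0-fold higher number (0.70 log units; beyond the scatter) from compound 1 to compound 2 and an at least 10-fold higher number (1.00 log units; beyond the scatter) from compound 3 to compound 4; the limit leaves it open whether they differ

Only two matched pairs are shown, so the result does not extend to other cores in the series. Also open, going by these compounds, is how the step would look with a carboxylic acid or a primary amine in place of the dimethylamino group.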